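Methoxy on the N-aryl ring of a thiazolidinone amide

The source may report more compounds than this note shows. Statements on the series, on what has been measured and on what is new or still open speak of the compounds shown alone.

Measured so far:
compound 1 `O=C(NCCCCc1ccccc1)c1cccc(C2SCC(=O)N2c2cccc(F)c2)c1` — 94%
compound 2 `O=C(NCCCCc1ccccc1)c1cccc(C2OCC(=O)N2c2cccc(F)c2)c1` — 87%
compound 3 `COc1ccccc1N1C(=O)CSC1C(=O)NCCCCc1ccccc1` — 0%

Of the compounds shown here, three have been tested in a functional assay on HOS-TE85 cells (Homo sapiens) for inhibition, read by CCK-8 assay, with a stated time of 72 h, tested at 1 uM; on this read-out higher numbers stand for more inhibition at the one concentration tested (going by the name of the read-out) and lower numbers for less inhibition. Compound 1 gives 94%, the highest of the three numbers, and compound 2 gives 87%, which lies within the scatter of compound 1, so the two cannot be ordered. Among the compounds with values here, compound 3, which carries a methoxy group on the aryl ring attached to the ring nitrogen and no fluoro group, gives 0%, far beyond the scatter from compound 1; since compound 3 differs from compound 1 in two places, no single step links them.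

Compound 4 `COc1ccc(F)cc1N1C(=O)CSC1c1cccc(C(=O)NCCCCc2ccccc2)c1` has not yet been measured. It differs from compound 1 in one place: methoxy in place of hydrogen on an aromatic carbon.

Within the data shown here, no step between measured compounds bears on this change alone. Among the measured compounds shown here, the only measured compound with a methoxy group on that ring, compound 3, gives 0%, which is taken as a warning rather than a rule. A drop in this assay from compound 1 to compound 4 is therefore expected, of about a number 54 percentage points lower from compound 1 to compound 4 (beyond the scatter), though with little confidence in its size. Compound 4 is estimated at 40%, in a range from 5% to 85%.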

Compound 4, a percentage reported as inhibition, at one concentration (the size of the read-out at that concentration, not a potency): 95%
The estimate for compound 4 lay 55 percentage points below the measured number; measured number outside the range, above it.
By their numbers in this assay, from the lowest: compound 3; then compounds 2, 1 and 4 (each within the scatter of the next).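

In this assay the change from 3-fluorophenyl to 5-fluoro-2-methoxyphenyl gives a number 1 percentage points higher from compound 1 to compound 4 (within the scatter), so methoxy in place of hydrogen at this place, ortho to a large group and para to a fluoro group, leaves no change that can be told from the usual scatter. The value of compound 3, 0%, can therefore no longer be read as a warning against a methoxy group on this ring as such, and since compound 3 differs from compound 4 in more than one place, what lies behind its value cannot be read from these compounds. Nothing measured here bears on why the methoxy group leaves the number within the scatter.

Going by these compounds, the read-out comes from one concentration and is not a potency, so whether compound 1 and compound 4 would separate at other concentrations stays open. Also open, on these data alone, is whether a hydroxy group, an ethoxy group or a dimethylamino group at the same place would hold the number, and whether the methoxy group would do so on the core of compound 2.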